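The source may hold more compounds than are shown below. What is called first, only, known or untested is meant among the compounds shown, and "the series" means these compounds.

Compound 1 `O=S1(=O)C=C(Sc2nnc(-c3cccnc3)o2)c2ccccc21`: 14000 nM
Compound 2 `COc1ccccc1-c1nnc(SC2=CS(=O)(=O)c3ccccc32)o1`: 16000 nM
Compound 3 `O=S1(=O)C=C(Sc2nnc(-c3ccccc3Cl)o2)c2ccccc21`: not yet measured

In an ADME assay on HepG2 cells (Homo sapiens) for cytotoxicity, read by fluorescence and resazurin assay, with a stated time of 24 h (on this read-out lower numbers stand for higher toxicity in this test and higher numbers for lower toxicity in this test), compound 1 gives 14000 nM and compound 2 gives 16000 nM, so the two values lie within the scatter of each other. Within the data shown here, compound 1 therefore stands level with the only other measured compound, and two values give little sense of the range this series can span.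

In compound 3, 2-chlorophenyl takes the place of pyridin-3-yl on an aromatic carbon of the five-membered aromatic ring with 2 nitrogen and 1 oxygen: 2-chlorophenyl in place of pyridin-3-yl on an aromatic carbon. Among the measured compounds shown here, one measured step bears on this change, a 1.1-fold higher number from compound 1 to compound 2 (0.06 log units; within the scatter), where 2-methoxyphenyl takes the place of pyridin-3-yl at the same carbon. For the measured compounds named here, that step stays within the scatter, but it is a single step, and no chlorine-bearing compound has been measured yet. No step beyond the scatter is therefore expected in this assay, and no direction is favoured. The expected step is no change at the digits printed from compound 1 to compound 3 (within the scatter).

Compound 3 is estimated at 14000 nM, with an expected range of 6500 nM to 30000 nM.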

Compound 3, half-maximal cytotoxic concentration: 25000 nM
Compound 3: middle estimate off by 1.8-fold (0.25 log units), on the low side, within the range that was stated.
By their numbers in this assay, from the lowest: compounds 1, 2 and 3 (each within the scatter of the next).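

With 2-chlorophenyl on this carbon of the five-membered aromatic ring, this assay gives a 1.8-fold higher number from compound 1 to compound 3 (0.25 log units; within the scatter), so a chlorine-bearing ring now joins 2-methoxyphenyl in a step from pyridin-3-yl that stays within the scatter. The exchange of chloro for methoxy on the phenyl ring gives a 1.6-fold higher number from compound 2 to compound 3 (0.19 log units; within the scatter), which adds a direct comparison of the two substituted phenyl groups and likewise stays within the scatter. Pyridin-3-yl, 2-methoxyphenyl and 2-chlorophenyl can therefore be treated as level at this position in this assay, and no measurement at hand offers an explanation for the small differences in the printed numbers.

All three groups shown are six-membered aromatic rings, so it remains open whether an aliphatic amine, a carboxylic acid or a longer alkyl chain on this carbon would give a step beyond the scatter. The compounds shown also leave open how far the number depends on the shared core, since every step here lies at this one carbon or on the ring attached to it.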